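Working notes: methyl-for-hydrogen steps and the unmeasured compound 4

The source may report more compounds than this note shows. Statements on the series, on what has been measured and on what is new or still open speak of the compounds shown alone.

Measured so far:
compound 1 `CCCCc1oc2ccccc2c1C(=O)c1ccc(OCCCC(=O)NCc2ccccc2)cc1` gives 15800 nM in a functional assay on U-937 cells (Homo sapiens) for antiproliferative activity, read by MTT assay, with a stated time of 24 h; on this read-out higher numbers stand for weaker inhibition and lower numbers for stronger inhibition
compound 2 `CCCCc1oc2ccccc2c1C(=O)c1ccc(OCCCC(=O)N[C@H](C)c2ccccc2)cc1` gives 30700 nM in this assay
compound 3 `CCCCc1oc2ccccc2c1C(=O)c1cc(I)c(OCCCN2CCN(C)CC2)c(I)c1` gives > 50000 nM in this assay

Compound 2 differs from compound 1 by methyl in place of hydrogen on a saturated chain carbon bound to an amide-type nitrogen and an aromatic carbon. In this assay this step is a 1.9-fold higher number from compound 1 to compound 2 (0.29 log units; within the scatter). The value of compound 3 is a limit of this assay and not a number. The difference between the core of compound 1 and the core of compound 3 is not broken down here.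

Compound 4, `CCCCc1oc2ccccc2c1C(=O)c1cc(I)c(OCCCN2CCN(CC)CC2)c(I)c1`, is not yet measured. It differs from compound 3 by methyl in place of hydrogen on a saturated chain carbon bound to an amine nitrogen in a ring. This is the same kind of change as from compound 1 to compound 2, not the same: there the place is a saturated chain carbon bound to an amide-type nitrogen and an aromatic carbon, here a saturated chain carbon bound to an amine nitrogen in a ring.

The expected step is a step that the limit leaves unreadable from compound 3 to compound 4, set beside the measured step of a 1.9-fold higher number from compound 1 to compound 2 (0.29 log units; within the scatter), which lies within the scatter.

This expectation rests on compound 3, whose result is only the limit > 50000 nM, so that a limit again seems the most likely outcome, see (the limit of > 50000 nM in this assay, at which 1 of the 3 values shown sits).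

Compound 4 is estimated at 70000 nM, with a range from 25000 nM to 200000 nM.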

Compound 4, half-maximal inhibitory concentration: 13700 nM
Beside the measured number, compound 4's estimate is 5.1-fold (0.71 log units) above it; measured number outside the range, below it.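

In this assay the new step is an at least 3.6-fold lower number from compound 3 to compound 4 (0.56 log units; beyond the scatter), with the methyl entering on a saturated chain carbon bound to an amine nitrogen in a ring, whereas on the core of compound 1 it enters on a saturated chain carbon bound to an amide-type nitrogen and an aromatic carbon. Set side by side, the same kind of change does not carry from one core to the other as a step of one size: the same change on two cores in this assay, a 1.9-fold higher number (0.29 log units; within the scatter) from compound 1 to compound 2 and an at least 3.6-fold lower number (0.56 log units; beyond the scatter) from compound 3 to compound 4, at least 7.0-fold (0.85 log units) apart, beyond the scatter of two such steps

Compound 3 gives > 50000 nM, which is a limit of the assay and not a number, so the exact size of the step stays unknown, and the two pairs do not separate the effect of the core from that of the place of the change: the limit of > 50000 nM in this assay, at which 1 of the 4 values shown sits.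

Open, as far as these compounds go, is whether a longer chain, such as propyl in place of the ethyl of the 4-ethylpiperazin-1-yl group, goes on lowering the number. Also open, from the compounds shown here alone, is how a (4-ethylpiperazin-1-yl)methyl end group and its methyl counterpart would read on the core of compound 1.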